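Swapping a Pyridyl Ring for a Dimethylamide

The source may hold more compounds than are shown below. What is called first, only, known or untested is meant among the compounds shown, and "the series" means these compounds.

Measured compounds:
compound 1 `CCCCN(c1nc2ccccc2o1)[C@H](C)c1ccc(-c2ccccc2-c2nnn[nH]2)cc1` gives 44.3 ng.h/mL in an ADME assay on the whole organism (Macaca fascicularis) for pharmacokinetics, read by LC-MS, using cassette dosing, at a dose of 1 mg/kg by the oral route; on this read-out higher numbers stand for higher exposure at the dose given and lower numbers for lower exposure
compound 2 `CCCCN(c1nc2c(-c3ccccn3)cccc2o1)[C@H](C)c1ccc(-c2ccccc2-c2nnn[nH]2)cc1` gives 248 ng.h/mL in this assay

Compound 2 has the highest of the two numbers in this assay; its nearest neighbour, compound 1, is separated from it by a 5.6-fold higher number from compound 1 to compound 2 (0.75 log units; beyond the scatter). For the measured compounds named here, that single step is the only measured change in this set, and it concerns putting a pyridin-2-yl onto the shared core.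

Compound 3 `CCCCN(c1nc2c(C(=O)N(C)C)cccc2o1)[C@H](C)c1ccc(-c2ccccc2-c2nnn[nH]2)cc1` is not yet measured. It differs from compound 2 by dimethylcarbamoyl in place of pyridin-2-yl on an aromatic carbon. Going by the values given here, no measured pair shows what a dimethylcarbamoyl at this position does; the only step that bears on it is the one from compound 1 to compound 2, which tells how much the pyridin-2-yl added over hydrogen, namely a 5.6-fold higher number from compound 1 to compound 2 (0.75 log units; beyond the scatter). Removing that group again and placing a smaller, non-aromatic substituent of the same acceptor count in its place leaves the outcome open. Compound 3 is therefore expected to sit between the two measured values, with the estimated step being a 2.5-fold lower number from compound 2 to compound 3 (0.39 log units; beyond the scatter). For compound 3 the estimate in this assay is 100 ng.h/mL, with a range from 30 ng.h/mL to 330 ng.h/mL.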

Compound 3, area under the concentration-time curve: 104 ng.h/mL
The estimate for compound 3 lay 1.0-fold (0.02 log units) below the measured number, and the stated range covers the measured number.
By their numbers in this assay, from the lowest: compound 1; then compound 3; then compound 2.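

In this assay, the dimethylcarbamoyl at this aromatic carbon keeps only part of what the pyridin-2-yl gained, with a 2.4-fold lower number from compound 2 to compound 3 (0.38 log units; beyond the scatter), yet it still improves on hydrogen, with a 2.3-fold higher number from compound 1 to compound 3 (0.37 log units; beyond the scatter). The gain at this position therefore does not depend on the pyridin-2-yl alone, since a substituent with no ring also lifts the number over that of the unsubstituted compound 1, though not as far as the aromatic ring does. Nothing available here accounts for the difference in exposure between the two groups.

From the compounds shown here alone, it remains open whether another group on this carbon, such as a primary carboxamide, a methoxy group or a phenyl ring, would match compound 2 or fall back towards compound 1. Going by these compounds, it is also open whether the order of hydrogen, dimethylcarbamoyl and pyridin-2-yl would hold at another dose or by another route of administration.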